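The source may hold more compounds than are shown below. What is called first, only, known or untested is meant among the compounds shown, and "the series" means these compounds.

- Compound 1 `CCCCNc1nc(SC)nc2ncccc12` gives 270 nM
- Compound 2 `CSc1nc(NC2CCCCC2)c2cccnc2n1` gives 5650 nM

Among the measured compounds shown here, in a functional assay (Nicotiana tabacum) (on this read-out higher numbers stand for weaker inhibition and lower numbers for stronger inhibition), compound 1 gives 270 nM as the lower of the two numbers so far, so it is the stronger inhibitor. Compound 3 `CCCCC(CC)CNc1nc(SC)nc2ncccc12` differs from compound 1 by one change (butyl in place of hydrogen on a saturated chain carbon bound to two saturated chain carbons). For the measured compounds named here, only one measured step bears on this change, and it was large: a 21-fold higher number from compound 1 to compound 2 (1.32 log units; beyond the scatter). That step replaced the chain with a ring, so it is only a loose guide. A smaller rise in the same direction is therefore expected, and the estimated step is a 2.6-fold higher number from compound 1 to compound 3 (0.41 log units; beyond the scatter). The estimated value for compound 3 is 700 nM, with an expected range from 130 nM to 4000 nM.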

Compound 3, half-maximal inhibitory concentration: 15900 nM
Compound 3: middle estimate off by 23-fold (1.36 log units), on the low side; measured number above the stated range.
By their numbers in this assay, from the lowest: compound 1; then compound 2; then compound 3.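

In this assay, adding a butyl branch on a saturated chain carbon bound to two saturated chain carbons gives a 59-fold higher number from compound 1 to compound 3 (1.77 log units; beyond the scatter). The nitrogen's substituent therefore need not become a ring for the number to climb: an open-chain group, with propyl becoming 1-ethylpentyl, also weakens inhibition. Nothing available here explains this rise.

The compounds shown leave open whether a shorter ethyl chain or a longer unbranched hexyl chain would give a lower number than compound 1. They also leave open how a chain ending in a hydroxyl group would behave.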